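Compound 3 to compound 4: a step from the limit

The compounds below may be only part of what the source reports. "The series", "measured", "known", "first", "only" and "open" are said of these compounds alone.

Measured compounds, each value a limit and not a number:
Compound 1 `C=C[C@@](C)(/C=C/c1ccc(Nc2cc(F)cc(F)c2)cc1)CCC=C(C)C`: > 43400 nM
Compound 2 `C=C[C@@](C)(/C=C/c1ccc(-c2ccccc2)cc1)CCC=C(C)C`: > 43400 nM
Compound 3 `C=C[C@@](C)(/C=C/c1ccc(-c2cccc(F)c2)cc1)CCC=C(C)C`: > 43400 nM

Compound 3 gives no number in a functional assay on NALM-6 cells (Homo sapiens) for cytotoxicity, with a stated time of 72 h; on this read-out lower numbers stand for an effect already at smaller amounts and higher numbers for an effect only at larger amounts of compound: its entry of > 43400 nM is a limit. Among the compounds with values here, all the compounds measured so far share this position, which is the limit of > 43400 nM in this assay, at which 3 of the 3 values shown sit.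

Compound 4 `C=C[C@@](C)(/C=C/c1ccc(-c2ccc(Cl)c(Cl)c2)cc1)CCC=C(C)C` carries 3,4-dichlorophenyl in place of 3-fluorophenyl on an aromatic carbon.

The closest measured change is a step that the two limits leave unreadable from compound 2 to compound 3, where fluoro replaces hydrogen on an aromatic carbon. The other two steps, a step that the two limits leave unreadable from compound 1 to compound 2 and a step that the two limits leave unreadable from compound 1 to compound 3, alter the same group more broadly. None of the three has a readable size, so no size or direction can be carried over to the new change.

Compound 4 is expected to be reported as a limit as well, because of the limit of > 43400 nM in this assay, at which 3 of the 3 values shown sit. The expected size is a step that the limit leaves unreadable from compound 3 to compound 4, with no direction expected beyond the scatter. For compound 4 the estimated value is 45000 nM, with an expected range from 25000 nM to 60000 nM.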

Compound 4, half-maximal effective concentration: > 43400 nM
Compound 4: no number, only a limit (the forecaster's own chance of this, stated with the estimate: 85%); the middle value lies beyond the limit too.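

In this assay compound 4 gives > 43400 nM, a limit and not a number, so its steps to compound 1, compound 2 and compound 3 cannot be read. The compounds shown leave open how far each lies beyond this limit, and whether any group at this place on the shared core gives a measurable value in this assay.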